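Adding a Second Methoxy to the Aryl Arm of Compound 1

The source may hold more compounds than are shown below. What is called first, only, known or untested is meant among the compounds shown, and "the series" means these compounds.

Measured compounds:
compound 1 `COc1ccc(-c2cc(/C=C/C(=O)c3ccc(N)cc3)[nH]n2)cc1` -68%
compound 2 `COc1cc(-c2cc(/C=C/C(=O)c3ccc(Cl)c(Cl)c3)[nH]n2)cc(OC)c1OC` -15%
compound 3 `COc1ccc(C(=O)/C=C/c2cc(-c3cc(OC)c(OC)c(OC)c3)n[nH]2)cc1` -16%

In a functional assay on CCRF-CEM cells (Homo sapiens) for cytotoxicity, read by sulforhodamine B assay, with a stated time of 48 h, tested at 100 uM (on this read-out higher numbers stand for a weaker effect at the one concentration tested and lower numbers for a stronger effect), compound 1 stands lowest of the three, with compound 3 next and compound 2 furthest, both beyond the scatter. Among the compounds with values here, the one measured step, a number 1 percentage points lower from compound 2 to compound 3 (within the scatter), concerns the carbonyl-side ring and not the ring changed here. Compound 4 `COc1ccc(-c2cc(/C=C/C(=O)c3ccc(N)cc3)[nH]n2)cc1OC` differs from compound 1 by methoxy in place of hydrogen on an aromatic carbon, placed ortho to a methoxy group and meta to a large group. Within the data shown here, no measured step bears on this change, so the expected step of a number 18 percentage points higher from compound 1 to compound 4 (beyond the scatter) is uncertain and could lie within the scatter. Compound 4 is therefore estimated at -50%, with a range from -85% to -10%.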

Compound 4, a percentage reported as activity, at one concentration (the size of the read-out at that concentration, not a potency): -22%
For compound 4 the middle estimate is 28 percentage points below the measured one, within the range that was stated.
By their numbers in this assay, from the lowest: compound 1; then compounds 4, 3 and 2 (each within the scatter of the next).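

In this assay, methoxy in place of hydrogen on this aromatic carbon, ortho to a methoxy group and meta to a large group, proves no silent change: a number 46 percentage points higher from compound 1 to compound 4 (beyond the scatter), a large step toward a weaker effect at the one concentration tested. Within the data shown here, the earlier compounds gave no step at this ring, so this is the first sign that this position matters. No measured evidence accounts for the step. As far as these compounds go, whether a hydroxyl, a fluorine or an ethoxy group on the same carbon would give a step of similar size remains open. So does whether methoxy would behave the same way with a carboxylic acid in place of the amine on the carbonyl-side ring.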